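This account rests on a few compounds, and the source may have more. Where it says the series, first, only, none or still open, it means among the compounds named here.

Series notes. Compound 1 `CC(C)N1CCN(Cc2csc(N)c2C(=O)c2ccc(Cl)cc2)CC1` carries isopropyl on the ring nitrogen, compound 2 `Nc1scc(CN2CCN(c3cc(Cl)cc(Cl)c3)CC2)c1C(=O)c1ccc(Cl)cc1` carries 3,5-dichlorophenyl there and compound 3 `Nc1scc(CN2CCN(c3ccncc3)CC2)c1C(=O)c1ccc(Cl)cc1` pyridin-4-yl. In a functional assay on CHO cells with adenosine receptor A1 (Homo sapiens) as the target, read by cAMP accumulation and immunoassay, with a stated time of 6 min, tested at 0.01 uM (on this read-out lower numbers stand for a stronger effect and higher numbers for a weaker effect at the one concentration tested), compound 1 gives -1%, compound 2 gives -1% and compound 3 gives -4%. Compound 3 stands lowest of the three numbers, yet every step to it lies within the scatter: a number 3 percentage points lower from compound 1 to compound 3 (within the scatter) and a number 3 percentage points lower from compound 2 to compound 3 (within the scatter); likewise no change at the digits printed from compound 1 to compound 2 (within the scatter). Compound 4 `Nc1scc(CN2CCN(c3ccc(F)cc3F)CC2)c1C(=O)c1ccc(Cl)cc1` differs from compound 3 by 2,4-difluorophenyl in place of pyridin-4-yl on an amine nitrogen in a ring. Within the data shown here, the nearest precedent is the exchange of one ring group for another on the same ring nitrogen, a number 3 percentage points lower from compound 2 to compound 3 (within the scatter), which moved nothing beyond the scatter, so no step beyond the scatter is expected in this assay. Compound 4 is therefore estimated at -2%, with a range from -12% to 8%. This corresponds to an expected step of a number 2 percentage points higher from compound 3 to compound 4 (within the scatter).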

Compound 4, a percentage reported as activity, at one concentration (the size of the read-out at that concentration, not a potency): 0%
The estimate for compound 4 lay 2 percentage points below the measured number; measured number inside the range.
By their numbers in this assay, from the lowest: compounds 3, 1, 2 and 4 (each within the scatter of the next).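

With 2,4-difluorophenyl on the ring nitrogen, this assay gives a number 4 percentage points higher from compound 3 to compound 4 (within the scatter), along with a number 1 percentage points higher from compound 2 to compound 4 (within the scatter) and a number 1 percentage points higher from compound 1 to compound 4 (within the scatter). Compared with pyridin-4-yl, this group has a ring of carbon only and no hydrogen-bond acceptor, yet the exchange stays within the scatter, so at this position the four compounds cannot be told apart in this read-out. Nothing available explains this flat result. Still open, as far as these compounds go, is whether a group of another kind on this nitrogen, such as a longer chain ending in a carboxylic acid, would give a step beyond the scatter.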